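Furan for ethoxyphenyl: a smaller ring on a shared core

The source may report more compounds than this note shows. Statements on the series, on what has been measured and on what is new or still open speak of the compounds shown alone.

Measured compounds:
Compound 1 `Cc1ccccc1-n1nc(C)c2c1NC(=O)[C@H](C)S[C@@H]2c1ccc(Oc2ccccc2C(=O)O)cc1` — "not active" (no number reported)
Compound 2 `Cc1ccccc1-n1nc(C)c2c1NC(=O)[C@H](C)S[C@@H]2c1ccc(/C=C/c2ccccc2)cc1` — "not active" (no number reported)
Compound 3 `CCOc1cccc(-c2ccc([C@H]3S[C@@H](C)C(=O)Nc4c3c(C)nn4-c3ccccc3C)cc2)c1` — 3500 nM

Among the compounds with values here, in an assay on isolated protein for agonist activity at Bile acid receptor (Homo sapiens), read by AlphaScreen, with a stated time of 30 min (a higher number here means that more compound is needed for the effect, a lower number that less compound is needed), compound 3 gives the only numerical value in this set; compound 1 and compound 2 each gave no number in this assay. Compound 4 `Cc1ccccc1-n1nc(C)c2c1NC(=O)[C@H](C)S[C@@H]2c1ccc(-c2ccoc2)cc1` shares the core of compound 3 and differs only in the group on an aromatic carbon of a six-membered carbon ring, para to a large group: furan-3-yl in place of 3-ethoxyphenyl on an aromatic carbon. Within the data shown here, no measured pair differs in just one place, so there is no step to anchor this change. The furan-3-yl ring is smaller than the 3-ethoxyphenyl it replaces, and the step from compound 3 is expected to be a modest weakening, a 2.0-fold higher number from compound 3 to compound 4 (0.30 log units; within the scatter), somewhat beyond the scatter. Compound 4 is therefore estimated at 7000 nM, with a range of 2000 nM to 25000 nM.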

Compound 4, half-maximal effective concentration: 3500 nM
Beside the measured number, compound 4's estimate is 2.0-fold (0.30 log units) above it, and the stated range covers the measured number.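

In this assay, within the data shown here, furan-3-yl in place of 3-ethoxyphenyl gives no change at the digits printed from compound 3 to compound 4 (within the scatter) and is the first step that can be read at this position, on an aromatic carbon para to a large group. Compound 4 thus shows that neither the ethoxy chain nor a six-membered ring is required here for a measurable value. Nothing shown accounts for this result. On these data alone, it remains open whether an amine or a morpholine ring at this position would also give a number, and whether furan-2-yl would match furan-3-yl.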